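The compounds below may be only part of what the source reports. "The series", "measured", "known", "first", "only" and "open" are said of these compounds alone.

- Compound 1 `COc1cc(N2CCN(C(=O)C3CCC(O)CC3)CC2)ccc1Nc1nc(NC2CCCCC2)c2nc[nH]c2n1`: 15 nM
- Compound 2 `COc1cc(N2CCC(C(=O)N3CCC(N(C)C)C3)CC2)ccc1Nc1nc(NC2CCCCC2)c2nc[nH]c2n1`: 58 nM

In a functional assay on HCT-116 cells (Homo sapiens) for cytotoxicity (a lower number here means a stronger inhibitor, a higher number a weaker inhibitor), compound 2 has the higher number of the two at 58 nM, a gap beyond the scatter from compound 1. Compound 3 `CCN(CC)CC1CCN(c2ccc(Nc3nc(NC4CCCCC4)c4nc[nH]c4n3)c(OC)c2)CC1` differs from compound 2 as follows: (diethylamino)methyl in place of (3-(dimethylamino)pyrrolidin-1-yl)carbonyl on a saturated ring carbon. It has (diethylamino)methyl in place of (3-(dimethylamino)pyrrolidin-1-yl)carbonyl on a saturated ring carbon. For the measured compounds named here, no measured pair isolates this change, so the expectation is uncertain: a modest step toward a lower number in this assay, possibly none beyond the scatter. The expected change is a 1.5-fold lower number from compound 2 to compound 3 (0.16 log units; within the scatter). For compound 3 the estimated value is 40 nM, with an expected range from 12 nM to 130 nM.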

Compound 3, half-maximal inhibitory concentration: 74 nM
For compound 3 the middle estimate is 1.9-fold (0.27 log units) below the measured one, within the range that was stated.
By their numbers in this assay, from the lowest: compound 1; then compounds 2 and 3 (each within the scatter of the next).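

In this assay, (diethylamino)methyl in place of (3-(dimethylamino)pyrrolidin-1-yl)carbonyl on this saturated ring carbon gives a 1.3-fold higher number from compound 2 to compound 3 (0.11 log units; within the scatter), which lies within the scatter. This position therefore tolerates losing both the carbonyl and the five-membered ring with no readable shift in this read-out. Nothing measured here accounts for this result.

The compounds shown leave open whether an amine nitrogen is needed on this ring carbon at all, since each of these two groups carries one. A hydroxyl or a carboxylic acid there could read quite differently.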